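A few compounds are considered here, and "the series" means these few. Any claim that something is new, unique, unknown or untested is made for them only; others in the source may bear on it.

In a functional assay on SMMC-7721 cells (Homo sapiens) for cytotoxicity, read by MTT assay, with a stated time of 24 h (on this read-out lower numbers stand for stronger inhibition and higher numbers for weaker inhibition), compound 1 `Cc1ccc(S(=O)(=O)N2C/C(=C\c3ccncc3)C(=O)/C(=C/c3ccccc3F)C2)cc1` gives 13200 nM and compound 2 `O=C1/C(=C/c2ccncc2)CN(S(=O)(=O)c2ccc([N+](=O)[O-])cc2)C/C1=C\c1ccccc1F` gives 15800 nM with the two values within the scatter of each other. Compound 3 `O=C1/C(=C/c2ccncc2)CN(S(=O)(=O)c2ccc(F)cc2)C/C1=C\c1ccccc1F` differs from compound 2 in one place: fluoro in place of nitro on an aromatic carbon with fluoro in place of nitro on an aromatic carbon, para to a large group. Going by the values given here, the one measured step at this place is a 1.2-fold higher number from compound 1 to compound 2 (0.08 log units; within the scatter) for nitro in place of methyl, and it lies within the scatter. Among the compounds with values here, no measured compound carries fluoro at this place, but no step beyond the scatter is expected in this assay for this change. Compound 3 is estimated at 14000 nM with an expected range of 7500 nM to 26000 nM in this read-out. This estimate means a 1.1-fold lower number from compound 2 to compound 3 (0.05 log units; within the scatter) as the expected step.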

Compound 3, half-maximal inhibitory concentration: > 20000 nM
Compound 3 gave a limit, no number (the forecaster's own chance of this, stated with the estimate: 3%); at least 1.4-fold (0.15 log units) between middle value and limit.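

In this assay compound 3 gives a limit, not a number: the limit of > 20000 nM in this assay, at which 1 of the 3 values shown sits.

Fluoro at this place therefore brings no stronger inhibition than nitro or methyl, with an at least 1.2-fold higher number from compound 2 to compound 3 (0.10 log units; that floor lies within the scatter) and an at least 1.5-fold higher number from compound 1 to compound 3 (0.18 log units; that floor lies within the scatter). Across methyl, nitro and fluoro, this position has so far shown no step beyond the scatter.

On these data alone, how far compound 3 lies past its limit remains unknown, so the true size of both steps stays open. Also open, as far as these compounds go, is whether an amine or a carboxylic acid at this place would give a lower number.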